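Adding Methoxycarbonyl to the Pyrrolidin-1-yl Ring of Compound 2

The source may report more compounds than this note shows. Statements on the series, on what has been measured and on what is new or still open speak of the compounds shown alone.

Compound 1: `COc1ccc(C[C@H]2COC(=O)[C@@H]2Cc2ccc(OCC(=O)Nc3ccccc3)c(OC)c2)cc1OC`, >= 600000 nM
Compound 2: `COc1ccc(C[C@H]2COC(=O)[C@@H]2Cc2ccc(OC(=O)CCC(=O)N3CCCC3)c(OC)c2)cc1OC`, 201000 nM

Among the compounds with values here, in an ADME assay on HeLa cells (Homo sapiens) for cytotoxicity, read by MTT assay (on this read-out higher numbers stand for weaker inhibition and lower numbers for stronger inhibition), compound 2 gives 201000 nM, the only number among the two values shown. For compound 1 the value is a limit of the assay, (the limit of >= 600000 nM in this assay, at which 1 of the 2 values shown sits). Within the data shown here, the one measured step, an at least 2.9-fold lower number from compound 1 to compound 2 (0.47 log units; beyond the scatter), concerns a different part of the molecule. Compound 3, `COC(=O)[C@@H]1CCCN1C(=O)CCC(=O)Oc1ccc(C[C@H]2C(=O)OC[C@@H]2Cc2ccc(OC)c(OC)c2)cc1OC`, differs from compound 2 by methoxycarbonyl in place of hydrogen on a saturated ring carbon. Among the measured compounds shown here, no measured step bears on this change, so no step beyond the scatter is expected: a 1.0-fold lower number from compound 2 to compound 3 (0.00 log units; within the scatter). Compound 3 is therefore expected to give 200000 nM, with a range from 80000 nM to 500000 nM.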

Compound 3, half-maximal inhibitory concentration: 145000 nM
Estimate against measurement, compound 3: 1.4-fold (0.14 log units) above; the measured number falls inside the stated range.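

Methoxycarbonyl on this saturated ring carbon, next to the ring nitrogen, is the first change shown on the pyrrolidin-1-yl ring, and in this assay it gives a 1.4-fold lower number from compound 2 to compound 3 (0.14 log units; within the scatter) for the added group. This ring carbon thus accepts the added methoxycarbonyl with no change beyond the scatter. Nothing available explains this result.

Going by these compounds, whether a carboxylic acid, a primary amide or a longer ester chain in place of methoxycarbonyl would move the number beyond the scatter remains open.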